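The compounds below may be only part of what the source reports. "The series", "measured", "known", "first", "only" and "open" are said of these compounds alone.

Compound 1 `COc1cc(-c2ccnc3cc(-c4cccc(C#N)c4)nn23)cc(OC)c1OC` reads > 10000 nM in a functional assay on HCT-116 cells (Homo sapiens) for inhibition, read by CCK-8 assay, with a stated time of 48 h (a higher number here means a weaker inhibitor, a lower number a stronger inhibitor), which is a limit of the assay and not a number. Compound 2 `COc1cc(-c2ccnc3cc(-c4ccccc4)nn23)cc(OC)c1OC` gives 3880 nM. Among the measured compounds shown here, compound 3 `COc1cc(-c2ccnc3cc(-c4ccc(C(F)(F)F)cc4)nn23)cc(OC)c1OC` gives 1860 nM, the lowest number so far. Compound 4 `CCOC(=O)c1ccc(-c2cc3nccc(-c4cc(OC)c(OC)c(OC)c4)n3n2)cc1` carries ethoxycarbonyl in place of trifluoromethyl on an aromatic carbon, para to a large group (ethoxycarbonyl in place of trifluoromethyl on an aromatic carbon). For the measured compounds named here, three measured steps bear on this: the modest 2.1-fold lower number from compound 2 to compound 3 (0.32 log units; beyond the scatter) on gaining trifluoromethyl, and the larger at least 2.5-fold lower number from compound 1 to compound 2 (0.41 log units; beyond the scatter) and an at least 5.3-fold lower number from compound 1 to compound 3 (0.73 log units; beyond the scatter) on losing the cyano-bearing ring. Losing trifluoromethyl should forfeit the gain of a 2.1-fold lower number from compound 2 to compound 3 (0.32 log units; beyond the scatter), so a modest rise is expected in this assay. The expected step is a 2.2-fold higher number from compound 3 to compound 4 (0.33 log units; beyond the scatter). For compound 4 the estimated value is 4000 nM, with an expected range of 1300 nM to 10000 nM.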

Compound 4, half-maximal inhibitory concentration: > 10000 nM
Compound 4: no number, only a limit (the forecaster's own chance of this, stated with the estimate: 15%); middle value at least 2.5-fold (0.39 log units) from the limit.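

In this assay, the group on the aromatic carbon para to a large group can move the number in either direction: ethoxycarbonyl in place of trifluoromethyl gives an at least 5.3-fold higher number from compound 3 to compound 4 (0.73 log units; beyond the scatter), and ethoxycarbonyl in place of hydrogen gives an at least 2.5-fold higher number from compound 2 to compound 4 (0.41 log units; beyond the scatter). Substitution here therefore does not lower the number in general, as trifluoromethyl did while ethoxycarbonyl did not. Both steps are floors, since the reading for compound 4 is a limit of the assay and not a number: the limit of > 10000 nM in this assay, at which 2 of the 4 values shown sit.

As far as these compounds go, how far compound 4 lies past that limit stays open. Also open, from the compounds shown here alone, is whether the carbonyl or the ethyl part goes with the rise, which a carboxylic acid or a primary amide at this position would help separate.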